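The source may report more compounds than this note shows. Statements on the series, on what has been measured and on what is new or still open speak of the compounds shown alone.

Measured so far:
- compound 1, `COC(=O)c1cc(N)c(Nc2ccc(C#N)cc2)cc1Oc1c(C)cc(/C=C/C#N)cc1C`: 4.72 h
- compound 2, `Cc1cc(CCC#N)cc(C)c1Oc1cc(Nc2ccc(C#N)cc2)c(N)cc1C(F)(F)F`: 0.928 h
- compound 3, `CNC(=O)c1cc(N)c(Nc2ccc(C#N)cc2)cc1Oc1c(C)cc(CCC#N)cc1C`: 0.928 h

In an in vitro ADME assay on microsomes from liver (Homo sapiens) for metabolic stability, tested at 1 uM (on this read-out higher numbers stand for a longer-lived compound and lower numbers for a shorter-lived compound), compound 3 stands level with compound 2, and together they are the lowest of the three numbers; compound 1 sits clearly higher, beyond the scatter. Within the data shown here, the one measured step that changes a single group, trifluoromethyl to methylcarbamoyl on an aromatic carbon, gave no change at the digits printed from compound 2 to compound 3 (within the scatter) in this assay.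

Compound 4, `COC(=O)c1cc(N)c(Nc2ccc(C#N)cc2)cc1Oc1c(C)cc(CCC#N)cc1C`, is not yet measured. It differs from compound 3 in one place: methoxy in place of methylamino on a carbonyl carbon

Among the measured compounds shown here, no measured step changes the group on the carbonyl carbon, so nothing directly bears on this change. Compound 1 also carries a methoxycarbonyl group, but it differs from compound 4 in more than one place, so it cannot be read as a clean comparison. For the measured compounds named here, the only single-group step, from compound 2 to compound 3, was flat. The expectation for compound 4 in this assay is therefore a step of a 1.6-fold higher number from compound 3 to compound 4 (0.21 log units; within the scatter), leaning slightly upward but not clearly beyond the scatter. Compound 4 is estimated at 1.5 h, with a range from 0.6 h to 4 h.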

Compound 4, half-life in the Homo sapiens assay: 3.1 h
Beside the measured number, compound 4's estimate is 2.1-fold (0.32 log units) below it, within the range that was stated.
By their numbers in the Homo sapiens assay, from the lowest: compounds 2 and 3 (each within the scatter of the next); then compounds 4 and 1 (each within the scatter of the next).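

Among these compounds, in the Homo sapiens assay, the carbonyl carbon turns out to matter: a 3.3-fold higher number from compound 3 to compound 4 (0.52 log units; beyond the scatter), the first step at this place, and it lies beyond the scatter, whereas the swap of trifluoromethyl for methylcarbamoyl had left the number flat. Methoxycarbonyl on the same aromatic carbon does separate from trifluoromethyl, with a 3.3-fold higher number from compound 2 to compound 4 (0.52 log units; beyond the scatter), while the change from 2-cyanoethenyl to 2-cyanoethyl gives only a 1.5-fold lower number from compound 1 to compound 4 (0.18 log units; within the scatter), which stays within the scatter, so compound 1's high number no longer stands apart from compound 4. The same swap of methylamino for methoxy reads the other way in a physicochemical assay for solubility, with a stated time of 4 h, at pH 7.4 (a higher number here means a more soluble compound, a lower number a less soluble compound), where compound 3 gives 8.28 ug/mL and compound 4 gives 1.21 ug/mL, so the longer half-life and the higher solubility sit on different compounds of this pair.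

As far as these compounds go, whether any group on this carbonyl carbon can hold both read-outs remains open, and ethoxy, dimethylamino or a free carboxylic acid at this place would test that. It is also unknown whether 2-cyanoethenyl and 2-cyanoethyl would stay this close alongside methylcarbamoyl rather than methoxycarbonyl.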